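The compounds below may be only part of what the source reports. "The series", "measured", "known", "first", "only" and "open" are said of these compounds alone.

Three compounds have been measured:

compound 1 `Clc1ccc(Sc2c(-c3ccc(Cl)cc3)[nH]c3ccc(Cl)cc23)cc1`, 31000 nM
compound 2 `OC1CCCN(C(=S)Sc2c(-c3ccc(Br)cc3)[nH]c3ccccc23)C1`, 24000 nM
compound 3 `Clc1ccc(Sc2c(-c3ccc(Cl)cc3)[nH]c3ccccc23)cc1`, 31000 nM

All three numbers come from a functional assay on Hs 683 cells (Homo sapiens) for inhibition, read by MTT assay, with a stated time of 72 h; on this read-out lower numbers stand for stronger inhibition of growth and higher numbers for weaker inhibition of growth. Compound 3 `Clc1ccc(Sc2c(-c3ccc(Cl)cc3)[nH]c3ccccc23)cc1` and compound 1 `Clc1ccc(Sc2c(-c3ccc(Cl)cc3)[nH]c3ccc(Cl)cc23)cc1` differ in one place only, (chloro in place of hydrogen on an aromatic carbon); the step of no change at the digits printed from compound 3 to compound 1 (within the scatter). Compound 2 `OC1CCCN(C(=S)Sc2c(-c3ccc(Br)cc3)[nH]c3ccccc23)C1` rests on another core, and how the core of compound 2 differs from the core of compound 3 is not broken down here. In this assay compound 2 gives 24000 nM, and this number, together with those of compound 1 and compound 3, lies within the scatter, so no order among the three can be read from the data.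

Compound 4 `OC1CCCN(C(=S)Sc2c(-c3ccc(Br)cc3)[nH]c3ccc(Cl)cc23)C1` has not yet been measured. It differs from compound 2 by chloro in place of hydrogen on an aromatic carbon, the same change as that made from compound 3 to compound 1; among the compounds shown this change occurs two times. Because the step of no change at the digits printed from compound 3 to compound 1 (within the scatter) left the number unchanged, compound 4 is expected to give a number close to that of compound 2 in this assay. For compound 4 the expected step is no change at the digits printed from compound 2 to compound 4 (within the scatter). This rests on a single measured pair on a different core, so the expectation is held loosely. The estimate for compound 4 in this assay is 24000 nM, with a range from 11000 nM to 52000 nM.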

Compound 4, concentration for 50% growth inhibition: 31000 nM
Compound 4: the middle estimate sits 1.3-fold (0.11 log units) below what was measured, within the range that was stated.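

In this assay, chloro in place of hydrogen on an aromatic carbon gives a 1.3-fold higher number from compound 2 to compound 4 (0.11 log units; within the scatter), and on the other core the same change gives no change at the digits printed from compound 3 to compound 1 (within the scatter). Set side by side, the two steps agree, so in this small set the change behaves alike on both cores: the same change on two cores in this assay, no change at the digits printed (within the scatter) from compound 3 to compound 1 and a 1.3-fold higher number (0.11 log units; within the scatter) from compound 2 to compound 4, 1.3-fold (0.11 log units) apart, within the scatter of two such steps What this shows is limited, however, since neither step can be told from the scatter: the two pairs agree only in that the change leaves no readable mark on either core, which does not show that a real effect carries from one core to the other, and two pairs say nothing about any further core.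

The compounds shown leave open whether another group on the same aromatic carbon, such as an amine or a carboxylic acid, would give a step beyond the scatter, and whether chloro on a different carbon of that ring would behave as it does here. They also leave open how the two cores compare with each other, as no pair shown differs only in the part that separates them, so no step between the cores can be read.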